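A few compounds are considered here, and "the series" means these few. Any claim that something is new, unique, unknown or untested is made for them only; others in the source may bear on it.

Of the compounds shown here, two with a shared core have been tested in an ADME assay on M210B4 cells (Mus musculus) for cytotoxicity, with a stated time of 48 h; on this read-out lower numbers stand for stronger inhibition and higher numbers for weaker inhibition. Compound 1 `CCCOc1ccccc1C(=O)/C=C/c1ccc2ccccc2c1` carries a propyl chain on an oxygen on an aromatic ring. In this assay compound 1 gives > 100000 nM, which is a limit of the assay and not a number. Compound 2 `CC(C)Oc1ccccc1C(=O)/C=C/c1ccc2ccccc2c1` has an isopropyl in place of the propyl on that oxygen. In this assay compound 2 gives > 100000 nM, again a limit of the assay rather than a number. The step that the two limits leave unreadable from compound 1 to compound 2 cannot be read in size. Compound 2 stands, like its partner, at the limit of > 100000 nM in this assay, at which 2 of the 2 values shown sit, with no number of its own.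

The change to compound 3 `Cc1ccccc1C(=O)/C=C/c1ccc2ccccc2c1` is methyl in place of isopropoxy on an aromatic carbon. Among the measured compounds shown here, no measured step bears on it in a readable way: the single step from compound 1 to compound 2 lies between two limits, so nothing is known about how far either compound sits past the limit. For the measured compounds named here, the only guide is that both measured compounds reach the limit. Compound 3 is expected to sit near the same limit, an estimated step of a number no higher from compound 2 to compound 3 (the limit leaves the size open). The estimate for compound 3 is 100000 nM, within 30000 nM to 300000 nM, and most likely reported again as a limit.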

Compound 3, half-maximal inhibitory concentration: 72000 nM
Estimate against measurement, compound 3: 1.4-fold (0.14 log units) above; the measured number falls inside the stated range.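

In this assay, among the compounds shown here, compound 3 is the first compound here with a number of its own, so a change on this aromatic carbon, ortho to a large group, can give a reading inside the range of the assay. Methyl in place of isopropoxy gives an at least 1.3-fold lower number from compound 2 to compound 3 (0.14 log units; that floor lies within the scatter), and methyl in place of propoxy gives an at least 1.3-fold lower number from compound 1 to compound 3 (0.14 log units; that floor lies within the scatter). Each of these steps is only a floor, so the swap of either oxygen-linked chain for methyl may be small or large, and the data do not show that it exceeds the usual scatter: the limit of > 100000 nM in this assay, at which 2 of the 3 values shown sit.

From the compounds shown here alone, the step between the propyl and isopropyl compounds stays unreadable, and how far compound 1 and compound 2 lie past their limit remains unknown, so the true size of the change to methyl is open. Also open, going by these compounds, is what an amine, a carboxylic acid or a longer chain on this same aromatic carbon would give, and whether any such group would bring the number down clearly beyond the scatter.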